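The source may hold more compounds than are shown below. What is called first, only, known or untested is meant among the compounds shown, and "the series" means these compounds.

Of the compounds shown here, three have been measured in a functional assay on CCRF-CEM cells (Homo sapiens) for cytotoxicity, with a stated time of 72 h; on this read-out higher numbers stand for weaker inhibition and lower numbers for stronger inhibition. Compound 1 `O=C1CCCC/C1=C\c1ccc([N+](=O)[O-])cc1` carries a single nitrophenyl group on its core and gives 19300 nM. Compound 2 `CN(C)c1ccc(/C=C2\CCC/C(=C\c3ccccc3[N+](=O)[O-])C2=O)cc1` bears two aromatic arms, one of them with a dimethylamino group, and gives 168000 nM. Compound 3 `COc1ccc(/C=C2\CCC/C(=C\c3ccccc3[N+](=O)[O-])C2=O)cc1` keeps the same frame but with a methoxy group in place of dimethylamino, and gives 7450 nM, the lowest of the three numbers; the gap a 23-fold lower number from compound 2 to compound 3 (1.35 log units; beyond the scatter) is a large one, well beyond the scatter.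

Compound 4 `O=C1/C(=C/c2ccc(F)cc2)CCC/C1=C\c1ccccc1[N+](=O)[O-]` is the next step from compound 3, with the difference (fluoro in place of methoxy on an aromatic carbon). Among the compounds with values here, the only measured step touching this same aromatic carbon is the one from compound 2 to compound 3, which was large, so this position can move the read-out considerably. Within the data shown here, no measured pair shows a fluoro group, however, so the direction here is uncertain. A modest shift toward a higher number is expected, a 1.6-fold higher number from compound 3 to compound 4 (0.21 log units; within the scatter), with the estimate for compound 4 placed at 12000 nM within a range of 3000 nM to 50000 nM.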

Compound 4, half-maximal inhibitory concentration in the CCRF-CEM assay: 1510 nM
The estimate for compound 4 lay 7.9-fold (0.90 log units) above the measured number; the measured number lies below the stated range.
By their numbers in the CCRF-CEM assay, from the lowest: compound 4; then compound 3; then compound 1; then compound 2.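

Among the three groups shown at this aromatic carbon, fluoro now gives the lowest number in the CCRF-CEM assay, with a 4.9-fold lower number from compound 3 to compound 4 (0.69 log units; beyond the scatter) and a 110-fold lower number from compound 2 to compound 4 (2.05 log units; beyond the scatter), so the position tolerates a much smaller group than methoxy without any rise in the number. In a physicochemical assay for lipophilicity (on this read-out lower numbers stand for lower lipophilicity and higher numbers for higher lipophilicity), compound 3 gives 4.86 and compound 4 gives 4.86, so this pair is separated in the cell assay but not on the partition coefficient. No measurement shown here accounts for the gaps between these groups.

The compounds shown leave open how chloro, a nitrile or a primary amine at this carbon would compare. They also leave open whether the same order of groups holds on the core of compound 1, since all three sit on one shared frame.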